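Swapping the Benzyl Group on Compound 1

The source may hold more compounds than are shown below. What is called first, only, known or untested is meant among the compounds shown, and "the series" means these compounds.

Measured in a functional assay on DU-145 cells (Homo sapiens) for cytotoxicity, read by MTT assay, with a stated time of 24 h; on this read-out higher numbers stand for weaker inhibition and lower numbers for stronger inhibition:
Compound 1 `COc1ccc(/C=C2\CN(Cc3cn(Cc4cccc(Cl)c4)nn3)C/C(=C\c3ccc(OC)cc3)C2=O)cc1`: 15400 nM
Compound 2 `O=C1/C(=C/c2ccccc2F)CN(C(=S)SCc2cn(Cc3ccccc3Cl)nn2)C/C1=C\c1ccccc1F`: 46300 nM
Compound 3 `Cc1ccc(/C=C2\CN(C(=S)SCc3cn(Cc4ccccc4F)nn3)C/C(=C\c3ccc(C)cc3)C2=O)cc1`: 80000 nM

Compound 1 has the lowest number of the three, so it is the most potent of this small set. Its gaps to compound 2 and to compound 3 both lie beyond the usual scatter of repeated measurements.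

The next compound to be tested is compound 4 `COc1ccc(/C=C2\CN(Cc3cn(Cc4ccccc4F)nn3)C/C(=C\c3ccc(OC)cc3)C2=O)cc1`. It keeps the core of compound 1 and changes one group: 2-fluorophenyl in place of 3-chlorophenyl on a saturated chain carbon bound to an aromatic nitrogen. In words, 2-fluorophenyl stands in place of 3-chlorophenyl on a saturated chain carbon bound to an aromatic nitrogen; cut one bond further out, this is 3-chlorobenzyl to 2-fluorobenzyl.

Among the measured compounds shown here, no two measured compounds differ in only one place, so the effect of such a swap has not been observed directly. Compound 3 also carries the 2-fluorobenzyl group and gives 80000 nM, but it differs from compound 1 elsewhere too, so it offers only a weak hint toward a higher number.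

In this assay, no step beyond the scatter is expected, and the estimate is a 1.4-fold higher number from compound 1 to compound 4 (0.13 log units; within the scatter). Compound 4 is expected at 21000 nM, with an estimated range from 9000 nM to 50000 nM.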

Compound 4, half-maximal inhibitory concentration: 32600 nM
For compound 4 the middle estimate is 1.6-fold (0.19 log units) below the measured one, and the stated range covers the measured number.
By their numbers in this assay, from the lowest: compound 1; then compounds 4, 2 and 3 (each within the scatter of the next, the first and the last beyond it).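

Among the compounds shown here, this is the first reading of a change at this position with the rest of the molecule held fixed. In this assay the swap of 3-chlorobenzyl for 2-fluorobenzyl on the core of compound 1 produces a 2.1-fold higher number from compound 1 to compound 4 (0.33 log units; beyond the scatter) and shows that this position responds to what the aromatic ring carries, although the step is modest. The response appears even though the two groups have the same number of heavy atoms and neither adds a hydrogen-bond donor or acceptor, and no measurement shown here explains why the number moves.

The halogen and its place on the ring change together in this single pair, so the step cannot be assigned to either one alone, and 2-chlorobenzyl or 3-fluorobenzyl on the same core would be needed to separate them. Also open, from the compounds shown here alone, is how this position would respond to a plain unsubstituted benzyl group, or to a benzyl group carrying an amine or a carboxylic acid.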